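The source may hold more compounds than are shown below. What is called first, only, known or untested is meant among the compounds shown, and "the series" means these compounds.

Compound 1 `Nc1nc(Br)cn2cc(-c3ccco3)nc12`: 28%
Compound 2 `Nc1nc(-c2ccccc2)cn2cc(-c3ccccc3)nc12`: 23%
Compound 3 `COc1ccc(-c2cn3cc(-c4ccccc4)nc(N)c3n2)cc1`: 27%

In an assay on cells for displacement of a labelled ligand from transmembrane domain-containing protein TMIGD3 (Homo sapiens), read by scintillation counting, with a stated time of 120 min, tested at 1 uM (on this read-out lower numbers stand for less inhibition and higher numbers for more inhibition at the one concentration tested (going by the name of the read-out)), compound 3 gives 27% and stands second highest of the three numbers. Its nearest neighbour is compound 1, which gives 28%, and its furthest is compound 2, which gives 23%; both gaps lie within the scatter. Going by the values given here, the one step that links two measured compounds, a number 4 percentage points higher from compound 2 to compound 3 (within the scatter), is also within the scatter.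

Compound 4 `Nc1nc(-c2ccccc2)cn2cc(-c3ccco3)nc12` differs from compound 3 in one place: furan-2-yl in place of 4-methoxyphenyl on an aromatic carbon. Among the compounds with values here, no measured step swaps these two groups at this position, so the only guide is that compound 1, which also carries a furan-2-yl, sits within the scatter of compound 3 and of compound 2, and that all three measured numbers fall in a narrow band. Compound 4 is therefore expected to show no step beyond the scatter, a number 1 percentage points lower from compound 3 to compound 4 (within the scatter), in either direction. The value of compound 4 in this assay is estimated at 26%, with a range from 14% to 38%.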

Compound 4, a percentage reported as inhibition, at one concentration (the size of the read-out at that concentration, not a potency): 21%
The estimate for compound 4 lay 5 percentage points above the measured number; the measured number falls inside the stated range.
By their numbers in this assay, from the lowest: compounds 4, 2, 3 and 1 (each within the scatter of the next).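

In this assay, the aromatic carbon of the five-membered aromatic ring with 2 nitrogen now has furan-2-yl compared directly with both six-membered aryl groups: furan-2-yl in place of 4-methoxyphenyl gives a number 6 percentage points lower from compound 3 to compound 4 (within the scatter), and furan-2-yl in place of phenyl gives a number 2 percentage points lower from compound 2 to compound 4 (within the scatter). Taken with a number 4 percentage points higher from compound 2 to compound 3 (within the scatter), these steps place phenyl, 4-methoxyphenyl and furan-2-yl within the scatter of one another at this carbon, despite the smaller ring of furan-2-yl. Going by these compounds alone, the first comparison at the other substituted carbon, phenyl in place of bromo, gives a number 7 percentage points lower from compound 1 to compound 4 (within the scatter), so this change also stays within the scatter.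

On these data alone, whether a morpholine or a carboxylic acid on either carbon would move the number beyond the scatter remains open. The same holds for an acetyl group on the shared amine, and no evidence is available to explain these numbers.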